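Nitro in place of trifluoromethyl on the benzyloxy arm

A few compounds are considered here, and "the series" means these few. Any claim that something is new, unique, unknown or untested is made for them only; others in the source may bear on it.

Compound 1, `c1ccc(COc2ccccc2Nc2ncnc3cc4c(cc23)OCCOCCO4)cc1`, gives > 100000 nM in a functional assay on DU-145 cells (Homo sapiens) for antiproliferative activity, read by MTT assay, with a stated time of 72 h (on this read-out higher numbers stand for weaker inhibition and lower numbers for stronger inhibition), a limit of the assay.
Compound 2, `FC(F)(F)c1ccc(COc2ccccc2Nc2ncnc3cc4c(cc23)OCCOCCO4)cc1`, gives > 100000 nM, likewise a limit.

The step that the two limits leave unreadable from compound 1 to compound 2 is therefore unreadable. Compound 2 stands at the limit of > 100000 nM in this assay, at which 2 of the 2 values shown sit. Compound 3, `O=[N+]([O-])c1ccc(COc2ccccc2Nc2ncnc3cc4c(cc23)OCCOCCO4)cc1`, differs from compound 2 by nitro in place of trifluoromethyl on an aromatic carbon. For the measured compounds named here, only the one measured step bears on this change, and its size cannot be read, so no direction in this assay is expected beyond the scatter. Compound 3 is expected to sit again at the limit, estimated at 100000 nM, between 30000 nM and 300000 nM. The expected step from compound 2 is thus a number no higher from compound 2 to compound 3 (the limit leaves the size open).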

Compound 3, half-maximal inhibitory concentration: 85600 nM
For compound 3 the middle estimate is 1.2-fold (0.07 log units) above the measured one, and the stated range covers the measured number.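

Of the three compounds, only compound 3 gives a number rather than a limit in this assay, so nitro at this place, para to a large group, makes the step readable as an at least 1.1-fold lower number from compound 2 to compound 3 (0.06 log units; that floor lies within the scatter). Set against the unsubstituted arm, the same group reads as an at least 1.1-fold lower number from compound 1 to compound 3 (0.06 log units; that floor lies within the scatter). Both steps are floors, so their true size stays open, and the other two compounds remain at a limit: the limit of > 100000 nM in this assay, at which 2 of the 3 values shown sit.

The compounds shown leave open whether an amine or a carboxylic acid on this aromatic carbon would move the number beyond the scatter. They also leave open what a longer chain in place of the benzyl link would do.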